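The source may hold more compounds than are shown below. What is called first, only, known or untested is meant among the compounds shown, and "the series" means these compounds.

The compounds share one core and were compared in a functional assay on MCF7 cells (Homo sapiens) for cytotoxicity, read by MTT assay, with a stated time of 72 h; on this read-out lower numbers stand for stronger inhibition and higher numbers for weaker inhibition. Compound 1 `O=C(Nc1ccc(Oc2ccnc3[nH]ccc23)cc1)c1cc(-c2ccccc2)ncn1` gives 20 nM. Compound 2 `O=C(Nc1ccc(Oc2ccnc3[nH]ccc23)c(F)c1)c1nccc(-c2ccc([N+](=O)[O-])cc2)n1` was reported as "not active" (no number reported). Compound 3 `O=C(Nc1ccc(Oc2ccnc3[nH]ccc23)c(F)c1)c1cc(-c2ccccc2)ncn1` gives 4640 nM, which is the highest of the two numbers reported, with compound 2 standing apart without a single number. Going by the values given here, the only measured step, a 230-fold higher number from compound 1 to compound 3 (2.37 log units; beyond the scatter), came from a fluoro in place of hydrogen on an aromatic carbon.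

Compound 4 `Cc1ccc(-c2cc(C(=O)Nc3ccc(Oc4ccnc5[nH]ccc45)c(F)c3)ncn2)cc1` differs from compound 3 by methyl in place of hydrogen on an aromatic carbon, para to a large group, or read one bond further out, phenyl to 4-methylphenyl. Among the compounds with values here, no measured step touches this place; the one step known concerns a fluoro on a different ring and so gives no guide here. In this assay compound 4 is therefore expected to show a 1.0-fold lower number from compound 3 to compound 4 (0.01 log units; within the scatter), nothing beyond the scatter, with an estimated 4500 nM and a likely range from 1500 nM to 14000 nM.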

Compound 4, half-maximal inhibitory concentration: 6730 nM
Compound 4: the middle estimate sits 1.5-fold (0.17 log units) below what was measured; measured number inside the range.
By their numbers in this assay, from the lowest: compound 1; then compounds 3 and 4 (each within the scatter of the next).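

In this assay, the change from phenyl to 4-methylphenyl gives a 1.5-fold higher number from compound 3 to compound 4 (0.16 log units; within the scatter), so this single methyl, para to a large group, makes no difference that can be told apart from repeat measurement. Going by these compounds alone, this is the first reading at this place, and unlike the earlier fluoro step, a 230-fold higher number from compound 1 to compound 3 (2.37 log units; beyond the scatter), this step stays within the scatter. No measurement shown offers an explanation for this result.

As far as these compounds go, both compounds in this step carry the fluoro, so it remains open whether the methyl would change as little on compound 1, which gives 20 nM. Also open, from the compounds shown here alone, is what other groups in this place would do, such as an amine, a methoxy group or a carboxylic acid.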